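The source may hold more compounds than are shown below. What is called first, only, known or untested is meant among the compounds shown, and "the series" means these compounds.

Measured so far:
compound 1 `COc1ccc(CS(=O)(=O)CC(=O)Nc2c(C)cc(C)cc2C)cc1[N+](=O)[O-]` gives > 30000 nM in a functional assay on T47D cells (Homo sapiens) for cytotoxicity, read by MTT assay, with a stated time of 72 h; on this read-out higher numbers stand for weaker inhibition of growth and lower numbers for stronger inhibition of growth — a limit, not a number
compound 2 `COc1cc(/C=C/S(=O)(=O)Cc2ccc(OC)c([N+](=O)[O-])c2)cc(OC)c1` gives > 30000 nM in this assay — a limit, not a number
compound 3 `COc1ccc(CS(=O)(=O)/C=C/c2ccc(OC)c(OC)c2OC)cc1N` gives 5900 nM in this assay

Compound 1 stands at the edge of what this assay reports: its value is a limit. Compound 2 also returns a limit, and together they sit at the limit of > 30000 nM in this assay, at which 2 of the 3 values shown sit, while compound 3 is the only one of the three with a measured number.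

The unmeasured compound 4 `COc1ccc(CS(=O)(=O)CC(=O)Nc2c(C)cc(C)cc2C)cc1N` differs from compound 1 in one place: amino in place of nitro on an aromatic carbon. Going by the values given here, no measured pair differs in only this one place, so the size of the step is not known directly. Compound 3, which carries an amino group on a different core, gives 5900 nM. Compound 2, which carries a nitro group, gives only a limit, > 30000 nM. Compound 4 is therefore expected to reach somewhat stronger inhibition of growth than a limit, estimated at 20000 nM, within a range from 6000 nM to 60000 nM. That estimate means an expected step of an at least 1.5-fold lower number from compound 1 to compound 4 (0.17 log units; that floor lies within the scatter), small enough that it may not exceed the scatter.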

Compound 4, concentration for 50% growth inhibition: > 30000 nM
Compound 4: a limit, no number; the forecaster's own chance of this, stated with the estimate: 55%; middle value at least 1.5-fold (0.17 log units) from the limit.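

Going by these compounds alone, compound 1 and compound 4 both return only a limit, so no step between them can be read: the limit of > 30000 nM in this assay, at which 3 of the 4 values shown sit. The compounds shown leave open whether amino in place of nitro changes inhibition of growth at all on the core of compound 1.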